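This account rests on a few compounds, and the source may have more. Where it says the series, first, only, none or still open, it means among the compounds named here.

Measured so far in a functional assay on MKN-45 cells (Homo sapiens) for cytotoxicity, read by MTT assay, with a stated time of 72 h; on this read-out higher numbers stand for weaker inhibition and lower numbers for stronger inhibition: compound 1 `COc1cc2c(Oc3ccc(NC(=O)c4cn(-c5ccc(Br)cc5)nn4)cc3F)ccnc2cc1OCCCN1CCCC1` gives 120 nM; compound 2 `COc1cc2c(Oc3ccc(NC(=O)c4cn(-c5ccccc5)nn4)cc3F)ccnc2cc1OCCCN1CCCCC1` gives 100 nM; compound 3 `COc1cc2c(Oc3ccc(NC(=O)c4cn(-c5ccccc5C)nn4)cc3F)ccnc2cc1OCCCN1CCCCC1` gives 3250 nM.

Compound 3 has the highest number of the three, with compound 1 nearest and compound 2 furthest, both well beyond the scatter. Compound 4 `COc1cc2c(Oc3ccc(NC(=O)c4cn(-c5ccc(Br)cc5)nn4)cc3F)ccnc2cc1OCCCN1CCCCC1` differs from compound 3 by 4-bromophenyl in place of 2-methylphenyl on an aromatic nitrogen. Among the measured compounds shown here, the one measured step that bears on this is a 33-fold higher number from compound 2 to compound 3 (1.51 log units; beyond the scatter), which shows the weight of the methyl on the phenyl. For the measured compounds named here, compound 1 and compound 2 carry no step between them, but their values are within the scatter of each other. A large step downward is therefore expected, a 30-fold lower number from compound 3 to compound 4 (1.47 log units; beyond the scatter). Compound 4 is estimated at 110 nM, within 40 nM to 300 nM.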

Compound 4, half-maximal inhibitory concentration: 150 nM
Compound 4: the middle estimate sits 1.4-fold (0.13 log units) below what was measured; the measured number falls inside the stated range.
By their numbers in this assay, from the lowest: compounds 2, 1 and 4 (each within the scatter of the next); then compound 3.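

In this assay, a 22-fold lower number from compound 3 to compound 4 (1.34 log units; beyond the scatter) shows that this aromatic nitrogen accepts 4-bromophenyl, while 2-methylphenyl stands apart from the other groups there. Bromo on the phenyl leaves no measurable difference, with a 1.5-fold higher number from compound 2 to compound 4 (0.18 log units; within the scatter), and with 4-bromophenyl in place, piperidin-1-yl and pyrrolidin-1-yl are not told apart, with a 1.3-fold higher number from compound 1 to compound 4 (0.10 log units; within the scatter). No measurement is available to explain these steps. Still open, as far as these compounds go, is whether 4-methylphenyl or 2-bromophenyl would stand with compound 4 or with compound 3, which would separate the identity of the group from its place on the phenyl.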